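The source may report more compounds than this note shows. Statements on the series, on what has been measured and on what is new or still open speak of the compounds shown alone.

Compound 1 `COCCOc1cc2oc(=O)n(CCC(=O)O)c2cc1Cl`: 70.7%
Compound 2 `Cc1ccc([C@@H](C)Oc2cc3oc(=O)n(CCC(=O)O)c3cc2Cl)nc1`: 97.8%

In an ADME assay on a cell-free system (plasma, Homo sapiens) for protein binding, compound 2 gives 97.8%, the lowest unbound fraction of the pair, while compound 1 gives 70.7%, a gap beyond the scatter. Compound 3 `C[C@@H](Oc1cc2oc(=O)n(CCC(=O)O)c2cc1Cl)c1cccnn1` carries pyridazin-3-yl in place of 5-methylpyridin-2-yl on a saturated chain carbon bound to an oxygen on an aromatic ring and a saturated chain carbon. Going by the values given here, no measured pair isolates this change, so the expectation rests on judgment. The expected step is a 4.5-fold higher unbound fraction from compound 2 to compound 3 (0.66 log units; beyond the scatter), toward a higher unbound fraction and beyond the scatter. For compound 3 the estimated value is 90%, with an expected range from 80% to 96%.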

Compound 3, plasma protein binding: 68.1%
Estimate against measurement, compound 3: 3.2-fold (0.50 log units) (unbound fraction) below, and the stated range ends above it.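

In this assay, pyridazin-3-yl in place of 5-methylpyridin-2-yl on the saturated chain carbon gives a large change (a 15-fold higher unbound fraction from compound 2 to compound 3 (1.16 log units; beyond the scatter)), so the read-out proves highly sensitive to the ring at this position. Going by these compounds alone, with pyridazin-3-yl there, the larger group on the oxygen on an aromatic ring no longer separates the compound from the small open-chain one (a 1.1-fold higher unbound fraction from compound 1 to compound 3 (0.04 log units; within the scatter)). The compounds shown change the methyl group and the ring nitrogens together, so they do not tell which of the two carries the step. As far as these compounds go, whether a plain pyridin-2-yl would stand with compound 2 or with compound 3 stays open, as does the outcome of an amine on that ring. Nothing measured here explains the step.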